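A Second Methoxy Group on Compound 1

The source may hold more compounds than are shown below. What is called first, only, known or untested is meant among the compounds shown, and "the series" means these compounds.

Measured compounds:
compound 1 `COc1ccc(-c2cc(/C=C/C(=O)c3ccc(N)cc3)[nH]n2)cc1` 52%
compound 2 `COc1cc(-c2cc(/C=C/C(=O)c3ccc(Cl)c(Cl)c3)[nH]n2)cc(OC)c1OC` 107%
compound 3 `COc1ccc(C(=O)/C=C/c2cc(-c3cc(OC)c(OC)c(OC)c3)n[nH]2)cc1` 80%

In a functional assay on OVCAR-4 cells (Homo sapiens) for cytotoxicity, read by sulforhodamine B assay, with a stated time of 48 h, tested at 1 uM (a higher number here means a weaker effect of the compound at the concentration tested, a lower number a stronger effect), compound 1 gives the lowest of the three numbers; compound 3 stands higher by a margin beyond the scatter, and compound 2 higher still. Compound 4 `COc1ccc(-c2cc(/C=C/C(=O)c3ccc(N)cc3)[nH]n2)cc1OC` differs from compound 1 by methoxy in place of hydrogen on an aromatic carbon. Going by the values given here, the only measured step, a number 27 percentage points lower from compound 2 to compound 3 (beyond the scatter), concerns the ring on a carbonyl carbon, not the ring that changes here, so it bears only loosely on the new step. Among the compounds with values here, no measured pair isolates an added methoxy on that ring; compounds 1 and 3 differ in two places. Compound 4 is therefore expected to give roughly the same result, a step of a number 8 percentage points higher from compound 1 to compound 4 (within the scatter) and a value of 60%, between 35% and 90%.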

Compound 4, a percentage reported as activity, at one concentration (the size of the read-out at that concentration, not a potency): 69%
Compound 4: the middle estimate sits 9 percentage points below what was measured; measured number inside the range.
By their numbers in this assay, from the lowest: compound 1; then compound 4; then compound 3; then compound 2.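

In this assay, methoxy in place of hydrogen, ortho to a methoxy group, gives a number 17 percentage points higher from compound 1 to compound 4 (beyond the scatter). This is the first single change shown on this ring, and it shows that the ring is not a silent spot: even a group of 2 heavy atoms here moves the number towards a weaker effect. Nothing measured gives a cause for this step. From the compounds shown here alone, whether a hydroxyl group or a fluorine atom in the same place would cost as much remains open. So does whether an ethoxy group, a longer chain, would cost more.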